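This account rests on a few compounds, and the source may have more. Where it says the series, first, only, none or still open, it means among the compounds named here.

Measured so far in an ADME assay on HEK293 cells (Homo sapiens) for cytotoxicity, read by fluorescence and resazurin assay, with a stated time of 24 h; on this read-out higher numbers stand for lower toxicity in this test and lower numbers for higher toxicity in this test:
compound 1 `COC(=O)c1ccc(-c2nnc(SC3=CS(=O)(=O)c4ccccc43)o2)cc1`, 4000 nM
compound 2 `Cc1ccc(-c2nnc(SC3=CS(=O)(=O)c4ccccc43)o2)cc1`, 3000 nM
compound 3 `O=S1(=O)C=C(Sc2nnc(-c3cccnc3)o2)c2ccccc21`, 4000 nM

Compound 3 stands level with compound 1 at the digits shown, and the step of a 1.3-fold higher number from compound 2 to compound 3 (0.12 log units; within the scatter) is within the scatter too, so all three numbers sit within the scatter of one another. The change on the other aromatic ring gave a 1.3-fold lower number from compound 1 to compound 2 (0.12 log units; within the scatter), also within the scatter.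

Compound 4 `O=S1(=O)C=C(Sc2nnc(-c3ccc(Cl)cc3)o2)c2ccccc21` differs from compound 3 by 4-chlorophenyl in place of pyridin-3-yl on an aromatic carbon. The measured step that bears on it is the one at the same place, a 1.3-fold higher number from compound 2 to compound 3 (0.12 log units; within the scatter), which stayed within the scatter; the step of a 1.3-fold lower number from compound 1 to compound 2 (0.12 log units; within the scatter) was within the scatter as well. Nothing in this series has moved the half-maximal cytotoxic concentration beyond the scatter, so no step beyond the scatter is expected for this change either. Compound 4 is therefore expected to give 3500 nM, with a range of 1500 nM to 8000 nM. The step this estimate means, a 1.1-fold lower number from compound 3 to compound 4 (0.06 log units; within the scatter), is expected to be none beyond the scatter.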

Compound 4, half-maximal cytotoxic concentration: 3000 nM
Compound 4: the middle estimate sits 1.2-fold (0.07 log units) above what was measured; the measured number falls inside the stated range.
By their numbers in this assay, from the lowest: compounds 2, 4, 1 and 3 (each within the scatter of the next).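

In this assay, the new result puts a ring of carbon only with chloro at this place on the five-membered aromatic ring, and 4-chlorophenyl in place of pyridin-3-yl stays within the scatter (a 1.3-fold lower number from compound 3 to compound 4 (0.12 log units; within the scatter)). On the phenyl ring, chloro is also within the scatter of methyl (no change at the digits printed from compound 2 to compound 4 (within the scatter)) and of methoxycarbonyl (a 1.3-fold lower number from compound 1 to compound 4 (0.12 log units; within the scatter)), so all four compounds now sit within the scatter of one another. No available measurement explains these steps.

On these data alone, it remains open whether an amine or a carboxylic acid on the phenyl ring, or a longer chain in place of the aromatic ring, would move the half-maximal cytotoxic concentration beyond the scatter. The compounds shown also leave the contribution of the shared core untested.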